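The compounds below may be only part of what the source reports. "The series", "measured", "known", "first", "only" and "open" are said of these compounds alone.

Series notes. Among the compounds with values here, compound 2 `O=C(O)CC/C=C\CC1COC(c2ccc3ccccc3c2)OC1c1cccnc1` gives 50 nM in an assay for inhibition of Thromboxane-A synthase (Homo sapiens), using microsomes (a higher number here means a weaker inhibitor, a lower number a stronger inhibitor), the highest of the two numbers so far, with compound 1 `O=C(O)CC/C=C\CC1COC(c2ccccc2Cl)OC1c1cccnc1` at 48 nM as its nearest neighbour. Within the data shown here, the only step in hand, a 1.0-fold higher number from compound 1 to compound 2 (0.02 log units; within the scatter), bears on the same saturated ring carbon and shows that position tolerating a change of group. Compound 3 `O=C(O)CC/C=C\CC1COC(c2cccc3ccccc23)OC1c1cccnc1` carries naphthalen-1-yl in place of naphthalen-2-yl on a saturated ring carbon. Among the measured compounds shown here, no measured step addresses this rearrangement of the same atoms, so the expectation rests on the tolerance already seen: a step of a 1.2-fold higher number from compound 2 to compound 3 (0.08 log units; within the scatter) is expected, not beyond the scatter. Compound 3 is estimated at 60 nM, within 25 nM to 150 nM.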

Compound 3, half-maximal inhibitory concentration: 40 nM
Compound 3: middle estimate off by 1.5-fold (0.18 log units), on the high side, within the range that was stated.
By their numbers in this assay, from the lowest: compounds 3, 1 and 2 (each within the scatter of the next).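

In this assay, the saturated ring carbon between two ring oxygen atoms does not distinguish the two naphthyl attachments: naphthalen-1-yl in place of naphthalen-2-yl gives a 1.3-fold lower number from compound 2 to compound 3 (0.10 log units; within the scatter). Naphthalen-1-yl in place of 2-chlorophenyl gives a 1.2-fold lower number from compound 1 to compound 3 (0.08 log units; within the scatter), so all three groups shown at this carbon read alike. Nothing at hand accounts for this tolerance.

All three groups at this carbon are aromatic rings of carbon. On these data alone, whether an amine, a carboxylic acid or an open alkyl chain at this carbon would keep the number in the same range remains open.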